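Trading a Naphthyl Group for a Tolyl Group

The compounds below may be only part of what the source reports. "The series", "measured", "known", "first", "only" and "open" are said of these compounds alone.

Compound 1, `COc1ccc(CO/N=C/c2c(-c3ccc4ccccc4c3)nc3occn23)cc1`: 4400 nM
Compound 2, `CC(C)(C)c1ccc(CO/N=C/c2c(-c3ccc4ccccc4c3)nc3occn23)cc1`: 7900 nM
Compound 3, `Clc1ccc(CO/N=C/c2c(-c3cccc4ccccc34)nc3sccn23)cc1Cl`: 940 nM

All three compounds were tested in an assay on HepG2 cells for agonist activity at nuclear receptor subfamily 1 group I member 3 (Homo sapiens), read by a luciferase reporter, with a stated time of 23 h; a lower number here means that less compound is needed, a higher number that more compound is needed for the effect. Among them compound 3 gives the lowest number; compound 1 lies well above it and compound 2 further still, and both gaps are beyond the usual scatter. Among the measured compounds shown here, the only measured step between close neighbours, a 1.8-fold higher number from compound 1 to compound 2 (0.25 log units; within the scatter), stays within that scatter and concerns the group on the benzyl ring, not the large aryl group attached to the shared core.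

Compound 4, `Cc1ccc(-c2nc3sccn3c2/C=N/OCc2ccc(Cl)c(Cl)c2)cc1`, has not yet been measured. It differs from compound 3 in a single place: 4-methylphenyl in place of naphthalen-1-yl on an aromatic carbon. For the measured compounds named here, no measured pair shows what happens when the bicyclic group is exchanged for the smaller one, so no step bears on it directly, and the expectation rests on the change alone. A smaller group entering is expected to need somewhat more compound, giving a 2.3-fold higher number from compound 3 to compound 4 (0.37 log units; beyond the scatter). Compound 4 is therefore estimated at 2200 nM, with a range from 600 nM to 8000 nM.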

Compound 4, half-maximal effective concentration: 490 nM
Compound 4: middle estimate off by 4.5-fold (0.65 log units), on the high side; the measured number lies below the stated range.
By their numbers in this assay, from the lowest: compounds 4 and 3 (each within the scatter of the next); then compounds 1 and 2 (each within the scatter of the next).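

Among the compounds shown here, the exchange of naphthalen-1-yl for 4-methylphenyl gives the first measured step at this aromatic carbon of the shared core: a 1.9-fold lower number from compound 3 to compound 4 (0.28 log units; within the scatter). The group that enters has one six-membered aromatic ring of carbon rather than two and fewer heavy atoms, yet the two numbers remain within the usual scatter of each other, so for this pair the second ring is not needed to keep the number in the same range. Nothing available explains why these two groups give such similar numbers.

For the compounds shown here, only two groups are compared at this position, so it stays open whether a longer chain, an amine or a carboxylic acid there would give a similar number. Also open, on these data alone, is how an unsubstituted phenyl ring would compare with 4-methylphenyl, and whether the exchange would give a similar step on a different benzyl ring.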